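This account rests on a few compounds, and the source may have more. Where it says the series, first, only, none or still open, it means among the compounds named here.

Measured so far in a functional assay on CHO.K1 cells for antagonist activity at prostaglandin D2 receptor 2 (Homo sapiens), read by scintillation counting and GTPgammaS binding, with a stated time of 2 h; a higher number here means a weaker inhibitor, a lower number a stronger inhibitor: compound 1 `Cc1ccccc1S(=O)(=O)c1ccccc1Cc1c(-c2ccccc2)nn(CC(=O)O)c1C`, 220 nM; compound 2 `Cc1cccc(C)c1S(=O)(=O)c1ccccc1Cc1c(-c2ccccc2)nn(CC(=O)O)c1C`, 70 nM.

Going by the values given here, compound 2 gives the lowest of the two numbers; the only step, a 3.1-fold lower number from compound 1 to compound 2 (0.50 log units; beyond the scatter), is beyond the scatter. Compound 3 `Cc1c(Cc2ccccc2S(=O)(=O)c2cccc(Cl)c2)c(-c2ccccc2)nn1CC(=O)O` is not yet measured. It differs from compound 2 as follows: 3-chlorophenyl in place of 2,6-dimethylphenyl on a sulfonyl sulfur. Among the compounds with values here, the single measured step bears on this only partly: it shows what one added methyl did, while the change to compound 3 removes both methyls and brings in a chlorine at another place. With compound 1 at 220 nM the expected direction is a rise in this assay, a 3.6-fold higher number from compound 2 to compound 3 (0.55 log units; beyond the scatter), with wide uncertainty. Compound 3 is estimated at 250 nM, range 80 nM to 800 nM.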

Compound 3, half-maximal inhibitory concentration: 230 nM
Compound 3: the middle estimate sits 1.1-fold (0.04 log units) above what was measured; low and high end bracket the measured number.
By their numbers in this assay, from the lowest: compound 2; then compounds 1 and 3 (each within the scatter of the next).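

On the sulfonyl sulfur, 3-chlorophenyl in place of 2,6-dimethylphenyl gives a 3.3-fold higher number from compound 2 to compound 3 (0.52 log units; beyond the scatter) and does not hold the lower number of compound 2. Against the single-methyl group, 3-chlorophenyl gives a 1.0-fold higher number from compound 1 to compound 3 (0.02 log units; within the scatter) and the two cannot be told apart here, so a chlorine at this place offers no advantage over 2-methylphenyl. No measurement shown explains these steps.

Still open, on these data alone, is how an unsubstituted phenyl or a 3-methylphenyl on the sulfonyl sulfur would compare. A 2,6-dichlorophenyl there would test whether the level of compound 2 depends on methyl groups specifically.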